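A few compounds are considered here, and "the series" means these few. Any claim that something is new, unique, unknown or untested is made for them only; others in the source may bear on it.

Compound 1, `C=CC[C@H]1C[C@]2([C@@H](C)Cc3cc(C#N)c(OC)cc3F)OCOC2=CC1=O`, gives 37 nM in a functional assay on M14 cells (Homo sapiens) for antiproliferative activity, with a stated time of 72 h; a higher number here means a weaker inhibitor, a lower number a stronger inhibitor.
Compound 2, `C=CC[C@H]1C[C@]2([C@@H](C)Cc3cc(F)c(OC)cc3F)OCOC2=CC1=O`, gives 30 nM in this assay.
Compound 3, `C=CC[C@H]1C[C@]2([C@H](C)Cc3cc(F)c(OC)cc3F)OCOC2=CC1=O`, gives 10 nM in this assay.

Compound 3 stands lowest of the three numbers in this assay. Two single-change steps lead there: a 1.2-fold lower number from compound 1 to compound 2 (0.09 log units; within the scatter), and a 3.0-fold lower number from compound 2 to compound 3 (0.48 log units; beyond the scatter), the latter resting on (the fact that compounds 2 and 3 differ only in the configuration as drawn). Compound 4, `C=CC[C@H]1C[C@]2([C@H](C)Cc3cc(O)c(OC)cc3F)OCOC2=CC1=O`, changes compound 3 by hydroxy in place of fluoro on an aromatic carbon. Among the compounds with values here, no measured step exchanges a fluoro for a hydroxy; the only exchange on the aromatic ring, cyano to fluoro, stayed within the scatter. The step in this assay from compound 3 to compound 4 is therefore expected to be small, a 2.0-fold higher number from compound 3 to compound 4 (0.30 log units; within the scatter), possibly in either direction. Compound 4 is estimated at 20 nM, within a range of 6 nM to 70 nM.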

Compound 4, half-maximal inhibitory concentration: 17 nM
Beside the measured number, compound 4's estimate is 1.2-fold (0.07 log units) above it; measured number inside the range.
By their numbers in this assay, from the lowest: compounds 3, 4, 2 and 1 (each within the scatter of the next, the first and the last beyond it).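

Placing hydroxy instead of fluoro on the aromatic carbon ortho to the methoxy group gives, in this assay, a 1.7-fold higher number from compound 3 to compound 4 (0.23 log units; within the scatter). Within the data shown here, this position, earlier seen only with cyano and fluoro, therefore also accepts a group carrying a hydrogen-bond donor, with no step beyond the scatter. Nothing available here gives a cause for this step.

The compounds shown leave open how an amine or a carboxylic acid would fare at this position. They also leave open whether hydroxy would behave the same way in the configuration of compound 2.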